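Swapping the Heteroaryl on the Amide Nitrogen Again

The compounds below may be only part of what the source reports. "The series", "measured", "known", "first", "only" and "open" are said of these compounds alone.

Compound 2 `Cc1ccc(OCC(=O)N(Cc2cccs2)c2nccn2C)cc1` sits at the high end of the two values on record in an assay on HEK293 cells for agonist activity at transient receptor potential cation channel subfamily M member 8 (Homo sapiens), read by fluorescence and calcium flux, with a stated time of 15 min; on this read-out higher numbers stand for an effect only at larger amounts of compound and lower numbers for an effect already at smaller amounts: compound 2 gives 1790 nM, while compound 1 `Cc1ccc(OCC(=O)N(Cc2cccs2)c2cccnc2)cc1` gives 198 nM. Among the compounds with values here, the one step on record, a 9.0-fold higher number from compound 1 to compound 2 (0.96 log units; beyond the scatter), came from a change of the heteroaryl on the amide-type nitrogen, so that position clearly matters. Compound 3 `Cc1ccc(OCC(=O)N(Cc2cccs2)c2cn[nH]c2)cc1` carries the change (1H-pyrazol-4-yl in place of 1-methyl-1H-imidazol-2-yl on an amide-type nitrogen). Within the data shown here, no measured pair shows this exact swap, so the expectation rests on the size of the step from compound 1 to compound 2 alone, which was modest. A step of comparable size in either direction is plausible; since compound 2 stands at the weak end, a move back toward compound 1 is somewhat more likely than a further rise. Compound 3 is therefore expected to give about 900 nM in this assay, between 250 nM and 3500 nM, an estimated change of a 2.0-fold lower number from compound 2 to compound 3 (0.30 log units; within the scatter).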

Compound 3, half-maximal effective concentration: 1.4 nM
Estimate against measurement, compound 3: 640-fold (2.81 log units) above; the whole stated range lies above it.
By their numbers in this assay, from the lowest: compound 3; then compound 1; then compound 2.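

The heteroaryl on the amide-type nitrogen proves far more decisive than the earlier pair suggested: in this assay, 1H-pyrazol-4-yl gives a 1300-fold lower number from compound 2 to compound 3 (3.11 log units; beyond the scatter) and also a 140-fold lower number from compound 1 to compound 3 (2.15 log units; beyond the scatter) in a single change. Compound 2 and compound 3 each carry one five-membered aromatic ring with 2 hetero atoms, yet they stand at opposite ends of the three values, so that ring description alone does not settle the result at this position. Nothing on record accounts for the size of this change.

The compounds shown leave open whether the result depends on the ring hydrogen-bond donor of 1H-pyrazol-4-yl, or on the arrangement of the ring itself. A 1-methyl-1H-pyrazol-4-yl or a 1H-imidazol-2-yl group on the same amide-type nitrogen would help separate the two.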